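Methylsulfonyl in place of chloro: working note on the series

This account rests on a few compounds, and the source may have more. Where it says the series, first, only, none or still open, it means among the compounds named here.

Measured so far:
Compound 1, `O=C(CCCc1ccc(Cl)cc1)N1CCc2c(Cl)c(O)c(O)c(Cl)c2C1`, gives 16% in a functional assay (Homo sapiens), tested at 10 uM; a higher number here means a weaker effect of the compound at the concentration tested, a lower number a stronger effect.
Compound 2, `O=C(CCCc1ccc(Cl)cn1)N1CCc2c(Cl)c(O)c(O)c(Cl)c2C1`, gives 15% in this assay.

Compound 2 and compound 1 lie within the scatter of each other in this assay, the step being a number 1 percentage points lower from compound 1 to compound 2 (within the scatter); on these two numbers compound 2 cannot be set apart from compound 1, and both show a strong effect at the concentration tested.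

Compound 3, `CS(=O)(=O)c1ccc(CCCC(=O)N2CCc3c(Cl)c(O)c(O)c(Cl)c3C2)nc1`, differs from compound 2 at one place: methylsulfonyl in place of chloro on an aromatic carbon. Among the compounds with values here, the only measured step, from compound 1 to compound 2, exchanged the ring bearing the chloro and left the chloro itself untouched, so it does not bear on the present change. Within the data shown here, no measured pair addresses a methylsulfonyl entering for a chloro, and the size of the step in this assay is therefore unknown in either direction; the range must be wide.

With nothing in the data arguing for a change, compound 3 is expected to give 25%, between 8% and 60%, which would mean an expected step of a number 10 percentage points higher from compound 2 to compound 3 (within the scatter).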

Compound 3, a percentage reported as activity, at one concentration (the size of the read-out at that concentration, not a potency): 72%
Estimate against measurement, compound 3: 47 percentage points below, and the stated range ends below it.
By their numbers in this assay, from the lowest: compounds 2 and 1 (each within the scatter of the next); then compound 3.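

The aromatic carbon para to a large group, two atoms from the ring nitrogen, is not indifferent to what it carries: in this assay methylsulfonyl in place of chloro gives a number 57 percentage points higher from compound 2 to compound 3 (beyond the scatter) and removes much of the strong effect seen at the concentration tested. The earlier step, a number 1 percentage points lower from compound 1 to compound 2 (within the scatter), changed the ring while keeping the chloro and left the two compounds indistinguishable, so the ring exchange and the exchange of the group on this carbon differ sharply in their consequences in this pair of steps. Nothing available bears on the reason for the large step, and the change of group cannot be tied to any one feature of methylsulfonyl.

Open, from the compounds shown here alone, is whether a methoxy, a nitrile or a plain hydrogen on this carbon would stay with compound 2 or move towards compound 3, which would show how narrow the demand at this position is. Also open, going by these compounds, is whether methylsulfonyl on the benzene ring of compound 1 would cost as much as it does on the ring of compound 2.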